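A few compounds are considered here, and "the series" means these few. Any claim that something is new, unique, unknown or untested is made for them only; others in the source may bear on it.

In an ADME assay on L6 cells (Rattus norvegicus) for cytotoxicity, read by resazurin assay, with a stated time of 72 h (on this read-out higher numbers stand for weaker inhibition and lower numbers for stronger inhibition), compound 1 `N/C(CC(O)c1cccc2ccccc12)=N\N=C\c1ccc(Cl)c(Cl)c1` gives 16000 nM and compound 2 `CCC/C(=N\N=C(/N)CC(O)c1cccc2ccccc12)c1ccccc1` gives 29000 nM so these two sit within the usual scatter of each other. Compound 3 `Cc1ccc(/C=N/N=C(\N)CC(O)c2ccc3ccccc3c2)cc1` gives 103000 nM which lies beyond the scatter from compound 1, on the higher side. Compound 4 `N/C(CC(O)c1cccc2ccccc12)=N\N=C\c1ccc(F)cc1` has not yet been measured. It keeps the core of compound 1 and differs in one place (4-fluorophenyl in place of 3,4-dichlorophenyl on a carbon with a double bond to nitrogen) with 4-fluorophenyl in place of 3,4-dichlorophenyl on a carbon with a double bond to nitrogen. Going by the values given here, no measured pair shows this change alone, so the expectation is loose: a modest rise in the number, possibly just beyond the scatter. The expected move is a 2.2-fold higher number from compound 1 to compound 4 (0.34 log units; beyond the scatter) and it remains an estimate. The estimated value for compound 4 is 35000 nM (expected range 14000 nM to 90000 nM).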

Compound 4, half-maximal inhibitory concentration: 19000 nM
Compound 4: middle estimate off by 1.8-fold (0.27 log units), on the high side, within the range that was stated.
By their numbers in this assay, from the lowest: compounds 1, 4 and 2 (each within the scatter of the next); then compound 3.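

In this assay, the step to 4-fluorophenyl in place of 3,4-dichlorophenyl on a carbon with a double bond to nitrogen is a 1.2-fold higher number from compound 1 to compound 4 (0.07 log units; within the scatter), so the two compounds cannot be told apart here. For this pair, the two chlorine atoms are not needed for a reading of this size. Nothing available explains this result.

Still open, going by these compounds, is whether a group of a different kind in place of 4-fluorophenyl on that carbon, such as an amine or a carboxylic acid, would give a number beyond the scatter.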